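Piperazine sulfonamide series: phenylethyl in place of tolyl

The source may hold more compounds than are shown below. What is called first, only, known or untested is meant among the compounds shown, and "the series" means these compounds.

Compound 1 `CCCn1c(=O)[nH]c2nc(-c3ccc(S(=O)(=O)N4CCN(c5ccccc5C)CC4)cc3)[nH]c2c1=O`: 419 nM in an assay on CHO cells for displacement of a labelled ligand from adenosine receptor A1 (Homo sapiens), read by scintillation counting, with a stated time of 90 min, in the presence of a further agent that is not named here; on this read-out higher numbers stand for weaker inhibition and lower numbers for stronger inhibition. Compound 2 `CCCn1c(=O)c2[nH]c(-c3ccc(S(=O)(=O)N4CCN(c5ccc(Cl)cc5)CC4)cc3)nc2n(C)c1=O`: > 1000 nM in this assay, a limit. Compound 3 `CCCn1c(=O)[nH]c2nc(-c3ccc(S(=O)(=O)N4CCN(c5ccccc5)C(C)C4)cc3)[nH]c2c1=O`: > 1000 nM in this assay, a limit.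

Within the data shown here, compound 1 carries the only definite number in this assay; the other two values are limits, as noted by the limit of > 1000 nM in this assay, at which 2 of the 3 values shown sit. Compound 4 `CCCn1c(=O)[nH]c2nc(-c3ccc(S(=O)(=O)N4CCN(C(C)c5ccccc5)CC4)cc3)[nH]c2c1=O` differs from compound 1 in one place: 1-phenylethyl in place of 2-methylphenyl on an amine nitrogen in a ring. Among the measured compounds shown here, no pair of measured compounds differing in a single place is available, so no measured step guides this change. The step of a 2.4-fold higher number from compound 1 to compound 4 (0.38 log units; beyond the scatter) is expected to run toward weaker binding and beyond the scatter, because the series is already crowded at the limit of > 1000 nM in this assay, at which 2 of the 3 values shown sit. Compound 4 is therefore estimated at 1000 nM, with a range from 300 nM to 3500 nM.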

Compound 4, inhibition constant: >= 1000 nM
Compound 4 was reported as a limit; the forecaster's own chance of this, stated with the estimate: 45%; the middle value sits exactly at the limit.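

Among these compounds, the change from 2-methylphenyl to 1-phenylethyl on this amine nitrogen in a ring gives the first single-place step, and in this assay it reads as an at least 2.3-fold higher number from compound 1 to compound 4 (0.37 log units; beyond the scatter). Compound 4 gives >= 1000 nM, which is a limit. The change yields another limit rather than a second definite number: the limit of >= 1000 nM in this assay, at which 1 of the 4 values shown sits.

As far as these compounds go, whether any group on this nitrogen gives a lower number than the 2-methylphenyl of compound 1 remains open. A benzyl or unbranched 2-phenylethyl group here would show whether the step follows the carbon link or the branch in 1-phenylethyl.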